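The source may report more compounds than this note shows. Statements on the series, on what has been measured and on what is new or still open speak of the compounds shown alone.

Three compounds on a shared core have been run in a functional assay on NCI-H520 cells (Homo sapiens) for inhibition, read by MTT assay, with a stated time of 48 h, tested at 10 uM; on this read-out higher numbers stand for more inhibition at the one concentration tested (going by the name of the read-out) and lower numbers for less inhibition. Compound 1 `COc1cc(NC(=O)Nc2cc(Nc3ccc(OC)c(C)c3)ncn2)cc(OC)c1` gives 13.5% and compound 2 `COc1cc(NC(=O)Nc2cc(Nc3cccc(C(C)(C)C)c3)ncn2)cc(OC)c1` gives 13.1%; the step of a number 0.4 percentage points lower from compound 1 to compound 2 (within the scatter) lies within the scatter, so these two read alike. Compound 3 `COc1cc(NC(=O)Nc2cc(Nc3ccc(OC)c(I)c3)ncn2)cc(OC)c1` gives 46.5%, the highest of the three numbers, set apart by a number 33 percentage points higher from compound 1 to compound 3 (beyond the scatter) and by a number 33.4 percentage points higher from compound 2 to compound 3 (beyond the scatter); both steps are large and beyond the scatter. The step from compound 3 to compound 4 `COc1cc(NC(=O)Nc2cc(Nc3cc(I)ccc3OC)ncn2)cc(OC)c1` is 5-iodo-2-methoxyphenyl in place of 3-iodo-4-methoxyphenyl on a nitrogen on an aromatic ring. The two compounds hold the same atoms, joined differently. Within the data shown here, no measured step moves a group around a ring; the two known large steps each bring iodo in where it was absent, and both raise inhibition strongly in this assay. Whether that rise survives with 5-iodo-2-methoxyphenyl in place of 3-iodo-4-methoxyphenyl on a nitrogen on an aromatic ring cannot be read from the data, so a fall of moderate size is expected, with wide uncertainty. For compound 4 the step is estimated as a number 16.5 percentage points lower from compound 3 to compound 4 (beyond the scatter). Compound 4 is therefore expected to give 30%, with a range from 10% to 55%.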

Compound 4, a percentage reported as inhibition, at one concentration (the size of the read-out at that concentration, not a potency): 55%
Beside the measured number, compound 4's estimate is 25 percentage points below it; measured number inside the range.
By their numbers in this assay, from the lowest: compounds 2 and 1 (each within the scatter of the next); then compounds 3 and 4 (each within the scatter of the next).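

In this assay, among these compounds, the first change that rearranges atoms without replacing any, 5-iodo-2-methoxyphenyl in place of 3-iodo-4-methoxyphenyl on a nitrogen on an aromatic ring, gives a number 8.5 percentage points higher from compound 3 to compound 4 (within the scatter) and so leaves the read-out unresolved from that of the earlier iodo compound. The high read-out is therefore not tied to the one arrangement first seen, since the second iodo-methoxy arrangement also stands well clear of the two compounds without iodo, with a number 41.9 percentage points higher from compound 2 to compound 4 (beyond the scatter) and a number 41.5 percentage points higher from compound 1 to compound 4 (beyond the scatter), and none of the four compounds goes against this split. No supporting measurement bears on why the two iodo arrangements read alike.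

Still open, as far as these compounds go, is whether iodo itself is required on the 5-iodo-2-methoxyphenyl group, or whether bromo, chloro or a nitrile in its place, or an ethoxy in place of the methoxy, would hold the read-out. All these numbers also describe inhibition at a single concentration, so they leave the potency of compound 3 and compound 4 unresolved.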